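Piperidine substituent on the shared core: hydroxy versus hydroxymethyl

A few compounds are considered here, and "the series" means these few. Any claim that something is new, unique, unknown or untested is made for them only; others in the source may bear on it.

Measured compounds in a functional assay on RKO cells (Homo sapiens) for antiproliferative activity, read by MTT assay, with a stated time of 5 days; a lower number here means a stronger inhibitor, a higher number a weaker inhibitor:
Compound 1, `COc1cc[nH]c1/C=C1\C(=O)Nc2ccc([N+](=O)[O-])cc21`: compound 1 gives 692 nM.
Compound 2, `COc1cc[nH]c1/C=C1\C(=O)Nc2ccc([N+](=O)[O-])c(N3CCC(N)CC3)c21`: compound 2 gives < 10 nM, which is a limit of the assay and not a number.
Compound 3, `COc1cc[nH]c1/C=C1\C(=O)Nc2ccc([N+](=O)[O-])c(N3CCCC(CO)C3)c21`: compound 3 gives 124 nM.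

Compound 3 holds the lowest of the two plain numbers in this assay; its nearest neighbour is compound 1, a step of a 5.6-fold lower number from compound 1 to compound 3 (0.75 log units; beyond the scatter) away. Against compound 2 the comparison runs an at least 12-fold higher number from compound 2 to compound 3 (1.09 log units; beyond the scatter), with the limit of < 10 nM in this assay, at which 1 of the 3 values shown sits, marking that this rests on a limit.

Compound 4 is `COc1cc[nH]c1/C=C1\C(=O)Nc2ccc([N+](=O)[O-])c(N3CCCC(O)C3)c21`. It differs from compound 3 by hydroxy in place of hydroxymethyl on a saturated ring carbon.

The measured steps that touch this position are a 5.6-fold lower number from compound 1 to compound 3 (0.75 log units; beyond the scatter) and an at least 12-fold higher number from compound 2 to compound 3 (1.09 log units; beyond the scatter); both change the whole group on the aromatic carbon, not the substituent on the saturated ring, so neither tests the present change directly. Within the data shown here, removing one carbon from a hydroxymethyl while keeping the hydroxy is a small cut, and no measured pair separates such a cut from the scatter. The expectation for compound 4 is therefore a step of a 1.2-fold higher number from compound 3 to compound 4 (0.08 log units; within the scatter), within the scatter, in either direction. Compound 4 is estimated at 150 nM, with a range from 50 nM to 450 nM.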

Compound 4, half-maximal inhibitory concentration: 105 nM
The estimate for compound 4 lay 1.4-fold (0.15 log units) above the measured number, and the stated range covers the measured number.
By their numbers in this assay, from the lowest: compounds 4 and 3 (each within the scatter of the next); then compound 1. At a limit, below all of these: compound 2.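

In this assay, the step at this saturated ring carbon, two ring bonds from the ring nitrogen, is a 1.2-fold lower number from compound 3 to compound 4 (0.07 log units; within the scatter), so hydroxy and hydroxymethyl cannot be told apart here, and the carbon that leaves with hydroxymethyl has no readable effect on this read-out. The change from hydrogen on the aromatic carbon survives the shorter group: a 6.6-fold lower number from compound 1 to compound 4 (0.82 log units; beyond the scatter) is a step of the same kind as a 5.6-fold lower number from compound 1 to compound 3 (0.75 log units; beyond the scatter), so the gain seen with 3-(hydroxymethyl)piperidin-1-yl does not depend on that extra carbon. The 4-aminopiperidin-1-yl group still stands apart, an at least 10-fold higher number from compound 2 to compound 4 (1.02 log units; beyond the scatter), and this step rests on a limit of the assay held by compound 2, not on a number: the limit of < 10 nM in this assay, at which 1 of the 4 values shown sits.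

The compounds shown do not separate the nature of the group from its place on the piperidine, since compound 2 differs from compound 3 and compound 4 in both. Going by these compounds, an amine on this same saturated ring carbon, in place of the hydroxy, would address that question, and how a carboxylic acid or a longer chain with a terminal hydroxy would read at this carbon also remains open.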